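Working notes: ethynyl in place of thiophen-3-yl

The compounds below may be only part of what the source reports. "The series", "measured", "known", "first", "only" and "open" are said of these compounds alone.

Measured so far:
Compound 1, `COc1ncnc2c1c(-c1ccsc1)cn2[C@@H]1O[C@H](CO)[C@@H](O)[C@H]1O`: in a functional assay on CCRF-CEM cells (Homo sapiens), read by MTT assay, with a stated time of 72 h (a higher number here means a weaker inhibitor, a lower number a stronger inhibitor), compound 1 gives 2570 nM.
Compound 2, `CNc1ncnc2c1c(-c1ccsc1)cn2[C@@H]1O[C@H](CO)[C@@H](O)[C@H]1O`: compound 2 gives > 20000 nM, which is a limit of the assay and not a number.
Compound 3, `Cc1ncnc2c1c(-c1ccsc1)cn2[C@@H]1O[C@H](CO)[C@@H](O)[C@H]1O`: compound 3 gives 11200 nM.

Compound 1 holds the lowest of the two numbers shown. Compound 3 sits further up, a 4.4-fold higher number from compound 1 to compound 3 (0.64 log units; beyond the scatter). Compound 2 sits at a limit, (the limit of > 20000 nM in this assay, at which 1 of the 3 values shown sits). The remaining step, an at least 1.7-fold lower number from compound 2 to compound 3 (0.25 log units; that floor lies within the scatter), has a floor that lies within the scatter. The step of an at least 7.7-fold higher number from compound 1 to compound 2 (0.89 log units; beyond the scatter) is the larger of the two changes at the methoxy carbon.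

Compound 4, `C#Cc1cn([C@@H]2O[C@H](CO)[C@@H](O)[C@H]2O)c2ncnc(OC)c12`, has not been measured in this assay. It differs from compound 1 in one place: ethynyl in place of thiophen-3-yl on an aromatic carbon. For the measured compounds named here, all three measured steps concern the carbon that bears methoxy, methylamino or methyl; none of them touches the carbon that bears thiophen-3-yl, so no measured step bears directly on the change to compound 4. The expectation therefore rests on compound 1 alone, with wide uncertainty and a direction that cannot be read from the shown steps. Compound 4 is expected near 4500 nM, in the range 1000 nM to 20000 nM. That corresponds to an expected step of a 1.8-fold higher number from compound 1 to compound 4 (0.24 log units; within the scatter).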

Compound 4, half-maximal inhibitory concentration: > 20000 nM
Compound 4: only a limit was reported (the forecaster's own chance of this, stated with the estimate: 20%); middle value at least 4.4-fold (0.64 log units) from the limit.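

In this assay compound 4 gives > 20000 nM, which is a limit of the assay and not a number. Ethynyl in place of thiophen-3-yl gives an at least 7.7-fold higher number from compound 1 to compound 4 (0.89 log units; beyond the scatter); this is the only measured change at this carbon, and it shows that, with methoxy held in place on the core, the group carried here matters to the read-out. The step is only a floor, and its true size cannot be read, as the limit now applies to compound 4 as well: the limit of > 20000 nM in this assay, at which 2 of the 4 values shown sit.

The compounds shown leave open how far compound 4 lies past the limit, and whether the step follows from losing the five-membered aromatic ring or from bringing in the triple bond, since ethynyl changes both at once. Going by these compounds, whether a phenyl ring, a furan-3-yl ring or a longer alkynyl chain on this carbon would hold the number near that of compound 1 also stays open, as does whether the same replacement would behave alike with methylamino or methyl on the core.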